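Benzoxaborole series: cytotoxicity notes on compounds 3 and 4

The source may hold more compounds than are shown below. What is called first, only, known or untested is meant among the compounds shown, and "the series" means these compounds.

Three benzoxaborole analogues have been run in an ADME assay on L929 cells (Mus musculus) for cytotoxicity, read by resazurin assay, with a stated time of 72 h (a higher number here means a weaker inhibitor, a lower number a stronger inhibitor), so far, and none of them returned a number. Compound 1 `OB1OCc2ccc(-n3cccc3Sc3ccc(Cl)cc3)cc21` gives > 10 ug/mL in this assay, which is a limit of the measurement rather than a value. Compound 2 `O=C(O)c1cccn1-c1ccc2c(c1)B(O)OC2` likewise gives > 10 ug/mL in this assay, again only a limit. Compound 3 `O=C(c1ccccc1)c1ccn(-c2ccc3c(c2)B(O)OC3)c1` also sits at a limit in this assay, with > 10 ug/mL, so its standing among the series can only be described as the limit of > 10 ug/mL in this assay, at which 3 of the 3 values shown sit; no ranking within the three is possible from this.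

Compound 4 `NCc1ccc(C(=O)c2ccn(-c3ccc4c(c3)B(O)OC4)c2)cc1` is the next analogue to be tested. It differs from compound 3 by aminomethyl in place of hydrogen on an aromatic carbon. Among the measured compounds shown here, no measured step with this change exists, so the expected direction has no precedent here. Because all three prior values sit at the limit of > 10 ug/mL in this assay, at which 3 of the 3 values shown sit, the working expectation is that compound 4 remains near the limit too, with an expected step that the limit leaves unreadable from compound 3 to compound 4 that is not beyond the scatter in either direction. Compound 4 is accordingly estimated at 15 ug/mL in this assay, within a range from 5 ug/mL to 40 ug/mL.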

Compound 4, half-maximal inhibitory concentration: > 10 ug/mL
Compound 4: a limit, no number; the forecaster's own chance of this, stated with the estimate: 70%; the middle value is on the limit's open side.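

The step from compound 3 to compound 4 cannot be read, since both results are limits and not numbers: the limit of > 10 ug/mL in this assay, at which 4 of the 4 values shown sit.

The compounds shown leave open what number any of them would give in this assay, and so whether aminomethyl in place of hydrogen changes anything there.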